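A few compounds are considered here, and "the series" means these few. Any claim that something is new, unique, unknown or untested is made for them only; others in the source may bear on it.

Compound 1 `COc1ccc(/C=C/C(=O)c2ccc(OC)c3c2OC(C)(C)C=C3)c(F)c1` gives > 10000 nM in a functional assay on HT-29 cells (Homo sapiens) for antiproliferative activity, read by MTT assay, with a stated time of 24 h (on this read-out lower numbers stand for stronger inhibition and higher numbers for weaker inhibition), which is a limit and not a number. Compound 3 `COc1ccc(C(=O)/C=C/c2ccc(-n3ccnc3)cc2)c2c1C=CC(C)(C)O2` gives > 6600 nM in this assay, also a limit. Within the data shown here, compound 2 `COc1ccc(C(=O)/C=C/c2ccc3ccccc3c2)c2c1C=CC(C)(C)O2` gives 4480 nM, the only true number among the three. Compound 1 therefore has no exact value to start from.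

Compound 4 `COc1ccc(/C=C/C(=O)c2ccc(OC)c3c2OC(C)(C)C=C3)cn1` carries 6-methoxypyridin-3-yl in place of 2-fluoro-4-methoxyphenyl on a double-bonded chain carbon bound to a double-bonded chain carbon. Among the measured compounds shown here, no measured pair sizes this change, so the expected step, a number no higher from compound 1 to compound 4 (the limit leaves the size open), is none beyond the scatter, and another limit would be no surprise. For compound 4 the estimated value is 10000 nM, with an expected range of 4000 nM to 25000 nM.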

Compound 4, half-maximal inhibitory concentration: > 10000 nM
Compound 4: no number, only a limit (the forecaster's own chance of this, stated with the estimate: 60%); the middle value sits exactly at the limit.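

Compound 1 and compound 4 both give only limits, not numbers, so no step between them can be read: the limit of > 10000 nM in this assay, at which 2 of the 4 values shown sit.

As far as these compounds go, whether 6-methoxypyridin-3-yl in place of 2-fluoro-4-methoxyphenyl shifts the read-out in this assay stays open.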